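The compounds below may be only part of what the source reports. "The series", "measured", "known", "first", "only" and "open" are said of these compounds alone.

Among the compounds with values here, in a functional assay on HT-29 cells (Homo sapiens) for cytotoxicity, read by neutral red uptake, with a stated time of 72 h (on this read-out lower numbers stand for stronger inhibition and higher numbers for weaker inhibition), compound 1 `CCCCCCNc1nc(SCC)nc2ncccc12` gives 22500 nM, the highest of the two numbers so far; compound 2 `CCCCCCCNc1nc(SCC)nc2ncccc12` gives 19900 nM, and a 1.1-fold lower number from compound 1 to compound 2 (0.05 log units; within the scatter). Compound 3 `CCCCCCNc1nc(SC(C)C)nc2ncccc12` differs from compound 1 by methyl in place of hydrogen on a saturated chain carbon bound to a saturated chain carbon and a sulfur. Within the data shown here, the only measured step, from compound 1 to compound 2, sits on the chain carbon six bonds from the ring nitrogen and not on the sulfur-bound carbon, so it bears on this change only loosely and was within the scatter. On that basis no step beyond the scatter is expected, a 1.1-fold lower number from compound 1 to compound 3 (0.05 log units; within the scatter). Compound 3 is estimated at 20000 nM, range 8000 nM to 50000 nM.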

Compound 3, half-maximal inhibitory concentration: 20200 nM
The estimate for compound 3 lay 1.0-fold (0.00 log units) below the measured number; the range from low to high includes it.
By their numbers in this assay, from the lowest: compounds 2, 3 and 1 (each within the scatter of the next).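

Compound 3 carries the only change shown on the sulfur-bound carbon: ethylsulfanyl to isopropylsulfanyl gives a 1.1-fold lower number from compound 1 to compound 3 (0.05 log units; within the scatter) in this assay and so leaves the number within the scatter. Methyl in place of hydrogen at this carbon therefore shows no step beyond the scatter, and the same holds for the chain change in compound 2. Nothing available bears on the reason for this result.

Still open, from the compounds shown here alone, is whether a benzyl group, a longer chain or a terminal amine on the sulfur would move the number beyond the scatter. The compounds shown also leave open whether any change on this core reaches a much lower number.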